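The compounds below may be only part of what the source reports. "The series", "measured", "known", "first", "only" and "open" are said of these compounds alone.

Measured in a functional assay on HBL-100 cells (Homo sapiens) for inhibition, read by sulforhodamine B assay, with a stated time of 48 h; a higher number here means a weaker inhibitor of growth, a lower number a stronger inhibitor of growth:

Compound 1 `COC(=O)[C@@]1(C)CCC=C2[C@@H]1CC[C@@H](C)[C@]2(C)Cc1c[nH]c2ccccc12` gives 4500 nM.
Compound 2 `COC(=O)[C@@]1(C)CCC=C2[C@@H]1CC[C@@H](C)[C@]2(C)Cc1c[nH]c2ccc(C)cc12` gives 18000 nM.

Compound 1 stands lowest of the two numbers, so it is the stronger growth inhibitor of the pair; compound 2 sits a clear step above it. For the measured compounds named here, the only measured step between these two, a 4.0-fold higher number from compound 1 to compound 2 (0.60 log units; beyond the scatter), shows that adding a small group on the aromatic carbon of the shared core costs potency.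

Compound 3 `COC(=O)[C@@]1(C)CCC=C2[C@@H]1CC[C@@H](C)[C@]2(C)Cc1c[nH]c2ccc(C(F)(F)F)cc12` carries a change at the same aromatic carbon as compound 2: trifluoromethyl in place of hydrogen on an aromatic carbon. The step from compound 1 to compound 2 is the one that bears on this, and it is modest but beyond the scatter, toward weaker inhibition. With no further data on the trifluoromethyl itself, a similar step in the same direction is the natural expectation, with room for it to be somewhat larger or smaller.

Compound 3 is therefore expected to give 15000 nM, within a range of 5000 nM to 45000 nM, an estimated step of a 3.3-fold higher number from compound 1 to compound 3 (0.52 log units; beyond the scatter).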

Compound 3, concentration for 50% growth inhibition: 15000 nM
Compound 3: the middle estimate sits on the measured number at the digits printed; the range from low to high includes it.
By their numbers in this assay, from the lowest: compound 1; then compounds 3 and 2 (each within the scatter of the next).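

In this assay, the loss of potency at this aromatic carbon is not tied to methyl alone: placing trifluoromethyl there in place of hydrogen gives a 3.3-fold higher number from compound 1 to compound 3 (0.52 log units; beyond the scatter) and weakens growth inhibition as well. Replacing methyl with trifluoromethyl gives a 1.2-fold lower number from compound 2 to compound 3 (0.08 log units; within the scatter) and so does not separate these two groups, while compound 1, with hydrogen at this carbon, remains the strongest of the three. The data offer no measurement that would explain why either group weakens growth inhibition.

Still open, going by these compounds, is whether a group of a different kind at this carbon, such as an amine, a carboxylic acid or a hydroxyl, would match or improve on hydrogen. On these data alone, whether trifluoromethyl or methyl would cost potency at other carbons of the same aromatic ring also remains unknown.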